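Swapping the Ring on Compound 2

The source may report more compounds than this note shows. Statements on the series, on what has been measured and on what is new or still open speak of the compounds shown alone.

Measured in a functional assay on L5178Y cells (Mus musculus) for antiproliferative activity, read by MTT assay; a higher number here means a weaker inhibitor, a lower number a stronger inhibitor:
- compound 1 `CC(C)(C)c1ccc(OCCCCN2CCN(c3ncccn3)CC2)cc1`: 11.3 nM
- compound 2 `CC(C)(C)c1ccc(OCCCCN2CCN(c3cccnc3)CC2)cc1`: 5.48 nM

Compound 2 has the lower of these two numbers, which makes it the stronger inhibitor of the pair. The next change gives compound 3 `CC(C)(C)c1ccc(OCCCCN2CCN(c3cnccn3)CC2)cc1`, with pyrazin-2-yl in place of pyridin-3-yl on an amine nitrogen in a ring. Among the measured compounds shown here, only one measured step bears on this, a 2.1-fold lower number from compound 1 to compound 2 (0.31 log units; beyond the scatter), and it is modest. One step is thin evidence. Still, pyrazin-2-yl looks more like the pyrimidin-2-yl of compound 1, at 11.3 nM, than like the group it replaces. A modest move towards a higher number in this assay is therefore expected, of about the size of that earlier step. The expected change is a 1.8-fold higher number from compound 2 to compound 3 (0.26 log units; within the scatter). The estimate for compound 3 is 10 nM, with an expected range from 4 nM to 25 nM.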

Compound 3, half-maximal inhibitory concentration: 9.86 nM
Estimate against measurement, compound 3: 1.0-fold (0.01 log units) above, and the stated range covers the measured number.
By their numbers in this assay, from the lowest: compounds 2, 3 and 1 (each within the scatter of the next, the first and the last beyond it).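

In this assay, this position gives a 1.8-fold higher number from compound 2 to compound 3 (0.26 log units; within the scatter), so this single swap of pyridin-3-yl for pyrazin-2-yl cannot be told apart from no change at all. Pyrazin-2-yl and pyrimidin-2-yl cannot be separated either, with a 1.1-fold lower number from compound 1 to compound 3 (0.06 log units; within the scatter), which leaves the gap between compound 1 and compound 2 as the only one of the three beyond the usual scatter. No measurement here explains why these rings compare as they do.

The compounds shown leave open how a phenyl ring, with no ring nitrogen at all, would compare at this position on the ring nitrogen. They also leave open whether a methyl group or an amine on the pyrazin-2-yl ring would move the number clearly away from that of compound 3.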